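Aryl variation on the amide nitrogen of a shared core

The source may report more compounds than this note shows. Statements on the series, on what has been measured and on what is new or still open speak of the compounds shown alone.

Measured compounds:
compound 1, `O=C(CSc1nc(Nc2ccccc2)c2ccccc2n1)Nc1ccccc1Br`, gives 10300 nM in a functional assay on NCI-H1975 cells (Homo sapiens) for inhibition, read by MTT assay, with a stated time of 72 h; a higher number here means a weaker inhibitor, a lower number a stronger inhibitor
compound 2, `O=C(CSc1nc(Nc2ccccc2)c2ccccc2n1)Nc1cccc(Cl)c1`, gives 8460 nM in this assay
compound 3, `C=CC(=O)Nc1cccc(NC(=O)CSc2nc(Nc3ccccc3)c3ccccc3n2)c1`, gives 8120 nM in this assay

Compound 3 holds the lowest of the three numbers, but its separation from the others is slight: a 1.0-fold lower number from compound 2 to compound 3 (0.02 log units; within the scatter) and a 1.3-fold lower number from compound 1 to compound 3 (0.10 log units; within the scatter) both fall within the scatter, so no ordering among the three is claimed.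

Compound 4, `O=C(CSc1nc(Nc2ccccc2)c2ccccc2n1)Nc1ccc(Cl)c(Cl)c1`, carries 3,4-dichlorophenyl in place of 3-((vinylcarbonyl)amino)phenyl on an amide-type nitrogen. Among the measured compounds shown here, two measured steps bear on this. The exchange of the group on the aromatic carbon, a 1.0-fold lower number from compound 2 to compound 3 (0.02 log units; within the scatter), changed nothing beyond the scatter, and the exchange of one halogen-bearing phenyl for another, a 1.2-fold lower number from compound 1 to compound 2 (0.09 log units; within the scatter), was likewise flat. Nothing in the series shows the aryl group on the amide nitrogen moving the number in this assay beyond the scatter, so for compound 4 a step of a 1.0-fold higher number from compound 3 to compound 4 (0.02 log units; within the scatter) is expected, that is, none beyond the scatter.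

Compound 4 is therefore estimated at 8500 nM in this assay, with a range of 4000 nM to 18000 nM.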

Compound 4, half-maximal inhibitory concentration: 10400 nM
Compound 4: middle estimate off by 1.2-fold (0.09 log units), on the low side; the range from low to high includes it.
By their numbers in this assay, from the lowest: compounds 3, 2, 1 and 4 (each within the scatter of the next).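

Exchanging the 3-((vinylcarbonyl)amino)phenyl for 3,4-dichlorophenyl on the amide-type nitrogen removes the vinylcarbonyl amide and its hydrogen-bond donor and acceptor, yet this assay shows no shift beyond the scatter (a 1.3-fold higher number from compound 3 to compound 4 (0.11 log units; within the scatter)). Placing chloro in place of hydrogen on an aromatic carbon is the series' first single-atom addition to this aryl group, and it is equally flat (a 1.2-fold higher number from compound 2 to compound 4 (0.09 log units; within the scatter)), as is the exchange of 2-bromophenyl for 3,4-dichlorophenyl (a 1.0-fold higher number from compound 1 to compound 4 (0.00 log units; within the scatter)). Nothing available explains why this position tolerates these exchanges without a measurable change.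

On these data alone, whether a non-aromatic group at the amide-type nitrogen, such as a longer alkyl chain, or an aryl group bearing an aliphatic amine or a carboxylic acid, would move the number remains open. Also open, as far as these compounds go, is whether changes to the shared core itself would move it further than any exchange on this aryl group.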